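The source may report more compounds than this note shows. Statements on the series, on what has been measured and on what is new or still open speak of the compounds shown alone.

Of the compounds shown here, three sharing one core have been measured in a functional assay on Fem-X cells (Homo sapiens) for cytotoxicity; a higher number here means a weaker inhibitor, a lower number a stronger inhibitor. Compound 1 `COC(=O)C1CCC2(CC1)OOC1(CCCCC1)OO2` gives 72400 nM. Compound 2 `NC(=O)C1CCC2(CC1)OOC1(CCCCC1)OO2` gives 120000 nM, and compound 3 `CCCNC(=O)C1CCC2(CC1)OOC1(CCCCC1)OO2` gives 102000 nM. Compound 2 therefore stands within the scatter of both other compounds, with a 1.7-fold higher number from compound 1 to compound 2 (0.22 log units; within the scatter) on one side and a 1.2-fold lower number from compound 2 to compound 3 (0.07 log units; within the scatter) on the other.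

The next compound to be tested is compound 4 `CN(C)CCNC(=O)C1CCC2(CC1)OOC1(CCCCC1)OO2`, which differs from compound 2 by 2-(dimethylamino)ethyl in place of hydrogen on an amide-type nitrogen. In words, it has 2-(dimethylamino)ethyl in place of hydrogen on an amide-type nitrogen. The closest measured precedent is the step that puts propyl in place of hydrogen at that same kind of nitrogen, a 1.2-fold lower number from compound 2 to compound 3 (0.07 log units; within the scatter). The related exchange of methoxy for propylamino on a carbonyl carbon, a 1.4-fold higher number from compound 1 to compound 3 (0.15 log units; within the scatter), is also small. So far, then, this assay has shown no step beyond the scatter among these compounds. However, none of them carries the 2-(dimethylamino)ethyl group, so the data cannot exclude a larger step, and the range is kept wide.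

No step beyond the scatter is expected, and the estimate is a 1.5-fold lower number from compound 2 to compound 4 (0.18 log units; within the scatter). Compound 4 is expected to give about 80000 nM, within an estimated range of 30000 nM to 160000 nM.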

Compound 4, half-maximal inhibitory concentration: 120000 nM
Compound 4: the middle estimate sits 1.5-fold (0.18 log units) below what was measured; the range from low to high includes it.
By their numbers in this assay, from the lowest: compounds 1, 3, 2 and 4 (each within the scatter of the next).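

In this assay, placing 2-(dimethylamino)ethyl on the amide-type nitrogen, whose other neighbour is the carbonyl carbon, gives no change at the digits printed from compound 2 to compound 4 (within the scatter) and thus adds a larger group with a nitrogen in its chain to the hydrogen and propyl seen there before. Dimethylamino in place of methyl on a saturated chain carbon, two bonds along the chain from the amide-type nitrogen, gives a 1.2-fold higher number from compound 3 to compound 4 (0.07 log units; within the scatter) while (2-(dimethylamino)ethyl)amino in place of methoxy on the carbonyl carbon gives a 1.7-fold higher number from compound 1 to compound 4 (0.22 log units; within the scatter) so this exchange also stays within the scatter from both the propyl amide and the methyl ester. No measurement is available that could explain this outcome.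

On these data alone, all four compounds lie within the scatter of one another, so it remains open whether any group on this nitrogen can move the number beyond the scatter. A carboxylic acid at the end of the chain, a primary amine in place of dimethylamino, or a longer chain between the amide-type nitrogen and the dimethylamino group could each test this.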